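Replacing 4-chlorophenyl with 1-methyl-1H-imidazol-2-yl in the series

A few compounds are considered here, and "the series" means these few. Any claim that something is new, unique, unknown or untested is made for them only; others in the source may bear on it.

In a functional assay for inhibition, with Homo sapiens as the target (on this read-out higher numbers stand for weaker inhibition and lower numbers for stronger inhibition), compound 2 (`COc1cc(OC)c(C(=O)/C=C/c2ccc(Cl)cc2)c(OC)c1`) gives 970 nM. Compound 1 (`COc1cccc(/C=C/C(=O)c2c(OC)cc(OC)cc2OC)c1`) gives 1800 nM, and compound 3 (`COc1cc(OC)c(C(=O)/C=C/c2c(Cl)cccc2Cl)c(OC)c1`) gives 1090 nM. Compound 2 cannot be separated from the other two: a 1.9-fold lower number from compound 1 to compound 2 (0.27 log units; within the scatter) and a 1.1-fold higher number from compound 2 to compound 3 (0.05 log units; within the scatter) both lie within the scatter, as does a 1.7-fold lower number from compound 1 to compound 3 (0.22 log units; within the scatter).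

Compound 4 (`COc1cc(OC)c(C(=O)/C=C/c2nccn2C)c(OC)c1`) carries 1-methyl-1H-imidazol-2-yl in place of 4-chlorophenyl on a double-bonded chain carbon bound to a double-bonded chain carbon. The three measured steps bear on this place, yet each only exchanges one substituted phenyl for another. Within the data shown here, no measured compound has a five-membered aromatic ring with 2 hetero atoms there, so they are a weak guide to this change. The flat steps argue against a large shift, while the new ring type leaves room for a modest loss. The expected step is a 2.3-fold higher number from compound 2 to compound 4 (0.36 log units; beyond the scatter), towards weaker inhibition and only slightly beyond the scatter. For compound 4 the estimate is 2200 nM, with an expected range of 700 nM to 7000 nM.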

Compound 4, half-maximal inhibitory concentration: 3800 nM
Compound 4: the middle estimate sits 1.7-fold (0.24 log units) below what was measured, within the range that was stated.
By their numbers in this assay, from the lowest: compounds 2, 3 and 1 (each within the scatter of the next); then compound 4.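

In this assay, this place on a double-bonded chain carbon bound to a double-bonded chain carbon now shows steps beyond the scatter: a 3.9-fold higher number from compound 2 to compound 4 (0.59 log units; beyond the scatter) and a 3.5-fold higher number from compound 3 to compound 4 (0.54 log units; beyond the scatter) and also a 2.1-fold higher number from compound 1 to compound 4 (0.32 log units; beyond the scatter) all point towards weaker inhibition. The three substituted phenyl groups remain within the scatter of one another, so the position separates the compounds shown only when 1-methyl-1H-imidazol-2-yl, a five-membered aromatic ring with 2 hetero atoms, enters. Nothing available explains this loss of inhibition.

As far as these compounds go, with a single compound of this ring type, it remains open whether the step belongs to the ring itself or to its methyl group, which 1H-imidazol-2-yl would separate. Also open, from the compounds shown here alone, is how a phenyl group carrying an amine or a carboxylic acid would compare at this place.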